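The compounds below may be only part of what the source reports. "The series", "measured", "known", "first", "only" and "open" are said of these compounds alone.

In a functional assay on MCF7 cells (Homo sapiens) for inhibition, read by MTT assay, with a stated time of 72 h (on this read-out higher numbers stand for weaker inhibition and lower numbers for stronger inhibition), compound 1 (`COc1cc(OC)c(OC)cc1/C=C/C(=O)c1ccc(Cl)cc1`) gives 29500 nM as its reading, and compound 3 (`COc1cc(OC)c(OC)cc1/C=C/C(=O)c1ccc(Cl)c([N+](=O)[O-])c1`) gives 16400 nM as its reading, so the two stand level. Compound 2 (`COc1cc(OC)c(-c2cc(=O)c3cc(Cl)ccc3o2)cc1OC`) returns no number, only the limit > 150000 nM as its entry.

Compound 4 (`COc1cc(OC)c(OC)cc1/C=C/C(=O)c1cc(O)ccc1O`) departs from compound 1 in one place: 2,5-dihydroxyphenyl in place of 4-chlorophenyl on a carbonyl carbon while the rest of the structure stays the same. Among the measured compounds shown here, the one measured step that bears on this change comes from compound 3, where a nitro on the 4-chlorophenyl gave a 1.8-fold lower number from compound 1 to compound 3 (0.25 log units; within the scatter) and nothing more. That step replaced only a hydrogen, whereas compound 4 exchanges the whole group, so it offers only loose guidance. On that basis no step beyond the scatter is expected in this assay for now, though the uncertainty is wide. The estimated change is a 1.5-fold lower number from compound 1 to compound 4 (0.17 log units; within the scatter) and is expected to be small. For compound 4 the expected value is 20000 nM with an estimated range from 5000 nM to 60000 nM as a first guess.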

Compound 4, half-maximal inhibitory concentration: > 150000 nM
Compound 4 gave a limit, no number; the forecaster's own chance of this, stated with the estimate: 5%; middle value at least 7.5-fold (0.87 log units) from the limit.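

Among the compounds shown here, putting 2,5-dihydroxyphenyl in place of 4-chlorophenyl on the carbonyl carbon gives an at least 5.0-fold higher number from compound 1 to compound 4 (0.70 log units; beyond the scatter) in this assay, the first step beyond the scatter. The earlier change on this group, adding a nitro, gave only a 1.8-fold lower number from compound 1 to compound 3 (0.25 log units; within the scatter), so it did not show that the reading could respond strongly to a change at this place. Compound 4 returns a limit, not a number, so the step has a floor but no measured size: the limit of > 150000 nM in this assay, at which 2 of the 4 values shown sit.

The change exchanges the whole group at once, and the compounds shown leave open whether the departure of the chlorine or the arrival of the two hydroxyl groups accounts for the step. Also open, going by these compounds, is how an unsubstituted phenyl or an aminophenyl on the carbonyl carbon would read.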